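Sulfonamide variation on a shared core: the arylsulfonyl position

This account rests on a few compounds, and the source may have more. Where it says the series, first, only, none or still open, it means among the compounds named here.

Of the compounds shown here, three have been measured so far, all sharing one core and differing only in the aryl group on the sulfonyl sulfur. Compound 1 `COc1ccc(S(=O)(=O)NC2=NCCN2C(=S)SN2CCn3c2nsc3=S)cc1OC` carries a 3,4-dimethoxyphenyl group there. In a functional assay on KYSE-510 cells (Homo sapiens) for antiproliferative activity, read by crystal violet staining, with a stated time of 96 h (a higher number here means a weaker inhibitor of growth, a lower number a stronger inhibitor of growth), compound 1 gives >= 20000 nM, which is a limit of the assay and not a number. Compound 2 `O=S(=O)(NC1=NCCN1C(=S)SN1CCn2c1nsc2=S)c1cccc(OC(F)(F)F)c1` gives >= 20000 nM in this assay, again a limit. Compound 3 `O=S(=O)(NC1=NCCN1C(=S)SN1CCn2c1nsc2=S)c1ccc(OC(F)(F)F)cc1` gives >= 20000 nM in this assay, also a limit. Within the data shown here, every value of the set therefore sits at the limit of >= 20000 nM in this assay, at which 3 of the 3 values shown sit, so no step between measured compounds can be read, and compound 1 stands level with the other two.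

Compound 4 `O=S(=O)(NC1=NCCN1C(=S)SN1CCn2c1nsc2=S)c1ccc2ccccc2c1` is not yet measured. It differs from compound 1 in one place: naphthalen-2-yl in place of 3,4-dimethoxyphenyl on a sulfonyl sulfur.

Among the measured compounds shown here, no measured step exists to anchor an expectation, and the three measured compounds show no compound reaching a numerical value in this assay. With each aryl variant so far at the limit, the expectation for compound 4 is no step beyond the scatter, with the step from compound 1 to compound 4 estimated as a number no higher from compound 1 to compound 4 (the limit leaves the size open). Compound 4 is accordingly expected at 20000 nM in this assay, within a range of 6000 nM to 40000 nM, most likely again reported only as a limit.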

Compound 4, concentration for 50% growth inhibition: >= 20000 nM
Compound 4: a limit, no number; the forecaster's own chance of this, stated with the estimate: 70%; the middle value sits exactly at the limit.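

In this assay compound 4 gives >= 20000 nM as a limit of the assay and not a number. Among these compounds, compound 1 also stands at a limit, so no step between compound 1 and compound 4 can be read: the limit of >= 20000 nM in this assay, at which 4 of the 4 values shown sit. The compounds shown leave open whether any aryl group on the sulfonyl sulfur of the shared core gives a numerical value in this assay.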